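A few compounds are considered here, and "the series" means these few. Any claim that something is new, unique, unknown or untested is made for them only; others in the source may bear on it.

In an assay on isolated protein for inhibition of Aromatase (Homo sapiens), read by fluorescence (a lower number here means a stronger inhibitor, a higher number a weaker inhibitor), compound 1, `N#Cc1ccc(S(=O)(=O)N2CCCC(Cn3ccnc3)C2)c(Cl)c1`, gives 79 nM. Compound 2, `N#Cc1ccc(S(=O)(=O)N2CCCC(Cn3ccnc3)C2)cc1`, differs from it by hydrogen in place of chloro on an aromatic carbon and in this assay gives 36 nM; the step of a 2.2-fold lower number from compound 1 to compound 2 (0.34 log units; beyond the scatter) is modest but beyond the scatter. Among the two numbers measured so far, compound 2 therefore stands lowest, with compound 1 as its only neighbour.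

Compound 3, `O=S(=O)(c1ccc(OC2CCCC2)cc1)N1CCCC(Cn2ccnc2)C1`, is not yet measured. Relative to compound 2 the change is cyclopentyloxy in place of cyano on an aromatic carbon. Among the compounds with values here, no measured step touches this position: the single step seen, from compound 1 to compound 2, concerns a chloro at a different aromatic carbon, and so offers no direct guide. The cyano is removed altogether and a considerably larger group enters in its place, and with nothing in the data to support such an exchange the number for compound 3 is expected to move upward rather than downward. The step of a 5.6-fold higher number from compound 2 to compound 3 (0.74 log units; beyond the scatter) is the estimate made here. Compound 3 is accordingly expected to give about 200 nM in this assay, within a range from 50 nM to 800 nM.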

Compound 3, half-maximal inhibitory concentration: 14 nM
Compound 3: middle estimate off by 14-fold (1.15 log units), on the high side; measured number outside the range, below it.
By their numbers in this assay, from the lowest: compound 3; then compound 2; then compound 1.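

On the aromatic carbon para to a large group, which the earlier step did not touch, cyclopentyloxy with its 6 heavy atoms replaces cyano with its 2, and this assay shows a 2.6-fold lower number from compound 2 to compound 3 (0.41 log units; beyond the scatter) rather than a loss. Between these two compounds, then, the nitrile is not required for a low number at this position, and a five-membered non-aromatic ring of carbon only can stand in its place with the number still falling by a modest step beyond the scatter. No accompanying measurement gives any account of the origin of this step.

The compounds shown leave open whether the oxygen or the carbon ring carries the change, since a plain methoxy, a cyclohexyloxy group or a cyclopentyl group attached directly to the aromatic carbon would separate the two. They also leave open how an amine such as a piperidine would compare at this position, and whether the step seen on removing the chloro would hold in the presence of cyclopentyloxy.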